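Methyl to methoxy on the aromatic ring: outlook for compound 4

This account rests on a few compounds, and the source may have more. Where it says the series, first, only, none or still open, it means among the compounds named here.

The series is read in a functional assay on BGC-823 cells (Homo sapiens) for inhibition, read by CCK-8 assay, with a stated time of 48 h; a lower number here means a stronger inhibitor, a higher number a weaker inhibitor. Compound 1 `COc1ccc(C2=NN(C3=NC(c4ccccc4)CS3)C(c3cccc4ccccc34)C2)cc1` gives 9510 nM. Compound 2 `O=C1CSC(N2N=C(c3ccc(Br)cc3)CC2c2cccc3ccccc23)=N1` gives 14600 nM. Compound 3 `Cc1ccc(C2=NN(C3=NC(=O)CS3)C(c3cccc4ccccc34)C2)cc1` gives 10000 nM, which places compound 3 second highest of the three numbers; its nearest neighbour is compound 1 and its furthest is compound 2, both within the scatter. Compound 1 and compound 3 differ in more than one place, so their two values are taken only as they stand.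

Compound 4 `COc1ccc(C2=NN(C3=NC(=O)CS3)C(c3cccc4ccccc34)C2)cc1` is not yet measured. It differs from compound 3 by methoxy in place of methyl on an aromatic carbon.

For the measured compounds named here, only one measured step touches this aromatic carbon: a 1.5-fold lower number from compound 2 to compound 3 (0.16 log units; within the scatter). That step exchanges a bromo for a methyl and stays within the scatter. The 4-methoxyphenyl group is also carried by compound 1, which differs from compound 3 elsewhere as well; the value of compound 3 is close to that of compound 1, which gives 9510 nM. Nothing here points to a step beyond the scatter for the exchange of methyl for methoxy, so in this assay compound 4 is expected to give 10000 nM, with a range from 5000 nM to 20000 nM. The step of no change at the digits printed from compound 3 to compound 4 (within the scatter) is the expected outcome, no movement beyond the scatter.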

Compound 4, half-maximal inhibitory concentration: 8210 nM
Beside the measured number, compound 4's estimate is 1.2-fold (0.09 log units) above it, within the range that was stated.
By their numbers in this assay, from the lowest: compounds 4, 1, 3 and 2 (each within the scatter of the next).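

In this assay, the exchange of 4-methylphenyl for 4-methoxyphenyl reads a 1.2-fold lower number from compound 3 to compound 4 (0.09 log units; within the scatter), and the exchange of bromo for methoxy on the same aromatic carbon reads a 1.8-fold lower number from compound 2 to compound 4 (0.25 log units; within the scatter), so bromo, methyl and methoxy at this carbon, para to a large group, are not separated beyond the scatter. With the 4-methoxyphenyl group held constant, the series also gains a single-place comparison at the amine nitrogen in a ring, where the smaller ring-bearing group stands in place of the larger one and the reading is a 1.2-fold lower number from compound 1 to compound 4 (0.06 log units; within the scatter), so this exchange also stays within the scatter. No measurement at hand offers an explanation for these steps.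

From the compounds shown here alone, whether an amine or a carboxylic acid on this aromatic carbon would give a step beyond the scatter remains open. Also open, going by these compounds, is whether methoxy would read the same with the ring-bearing group of compound 1 exchanged for another group at the amine nitrogen, such as one carrying a longer chain.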